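Methyl in place of methoxy: expectation for compound 4

A few compounds are considered here, and "the series" means these few. Any claim that something is new, unique, unknown or untested is made for them only; others in the source may bear on it.

In a functional assay on C6 cells (Rattus norvegicus) for cytotoxicity, read by MTT assay, with a stated time of 24 h, tested at 12 ug/mL (on this read-out higher numbers stand for a weaker effect at the one concentration tested and lower numbers for a stronger effect), compound 3 `COc1ccc(-c2cs/c(=N/NC(=O)CSc3nnc(C)s3)n2-c2ccccc2)cc1` gives 53.6%, the lowest of the three numbers recorded so far. Compound 1 `Cc1nnc(SCC(=O)N/N=c2/scc(-c3ccc(F)cc3)n2-c2ccccc2)s1` gives 73.7% and compound 2 `Cc1ccc(-c2cs/c(=N/NC(=O)CSc3nncn3C)n2-c2ccccc2)cc1` gives 72%, each beyond the scatter above compound 3. Going by the values given here, the only single-point step measured is a number 20.1 percentage points lower from compound 1 to compound 3 (beyond the scatter); it is also the only step that changes the group on the six-membered aromatic ring of carbon only, and it bears directly on the present question.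

Compound 4 `Cc1ccc(-c2cs/c(=N/NC(=O)CSc3nnc(C)s3)n2-c2ccccc2)cc1` differs from compound 3 by methyl in place of methoxy on an aromatic carbon. Among the compounds with values here, no measured pair shows methyl replacing methoxy. Compound 2 carries the same 4-methylphenyl but differs from compound 4 elsewhere, so compound 2 with 72% gives only a loose pointer. Since the methoxy group arrived with the downward step from compound 1, its removal is expected to give back part of that move: a modest rise, estimated as a number 12.4 percentage points higher from compound 3 to compound 4 (beyond the scatter), with an uncertainty wide enough that no change beyond the scatter is also possible. Compound 4 is therefore expected at 66%, within 52% to 80%.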

Compound 4, a percentage reported as activity, at one concentration (the size of the read-out at that concentration, not a potency): 58.3%
Beside the measured number, compound 4's estimate is 7.7 percentage points above it; the measured number falls inside the stated range.
By their numbers in this assay, from the lowest: compounds 3 and 4 (each within the scatter of the next); then compounds 2 and 1 (each within the scatter of the next).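

In this assay, methyl in place of methoxy gives a number 4.7 percentage points higher from compound 3 to compound 4 (within the scatter), so the 4-methoxyphenyl and 4-methylphenyl groups are not told apart on this core, and the replacement of fluoro by methyl also gives a number 15.4 percentage points lower from compound 1 to compound 4 (beyond the scatter), which matches the earlier step away from fluoro to methoxy. The group on the sulfur also counts, since the 5-methyl-1,3,4-thiadiazol-2-yl in place of 4-methyl-4H-1,2,4-triazol-3-yl gives a number 13.7 percentage points lower from compound 2 to compound 4 (beyond the scatter) with the 4-methylphenyl held fixed. No data here bear on the reason for these steps.

From the compounds shown here alone, what an amine or a carboxylic acid on this aromatic carbon would do to the read-out remains open. Also open, going by these compounds, is whether the step away from fluoro carries over with 4-methyl-4H-1,2,4-triazol-3-yl on the sulfur.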